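The source may report more compounds than this note shows. Statements on the series, on what has been measured and on what is new or still open speak of the compounds shown alone.

In a functional assay on DU-145 cells (Homo sapiens) for cytotoxicity, read by MTT assay, with a stated time of 24 h (on this read-out lower numbers stand for stronger inhibition and higher numbers for weaker inhibition), compound 1 (`CCCCCCCCCC(=O)Nc1nnc(S[C@@H]2O[C@H](CO)[C@H](O)[C@H](O)[C@H]2O)s1`) is reported as "not active" (no number reported) and so offers no number from which to measure a step. For the measured compounds named here, only two relatives carry numbers: compound 2 (`CCCCCCCC/C=C\CCCCCCCCCCCC(=O)Nc1nnc(S[C@@H]2O[C@H](COC(C)=O)[C@H](OC(C)=O)[C@H](OC(C)=O)[C@H]2OC(C)=O)s1`) gives 28400 nM and compound 3 (`CCCCCCCCCCCCCCCCCC(=O)Nc1nnc(S[C@@H]2O[C@H](COC(C)=O)[C@H](OC(C)=O)[C@H](OC(C)=O)[C@H]2OC(C)=O)s1`) gives 31200 nM in the same test. Compound 4 (`CCCCCCCCCCCC(=O)Nc1nnc(S[C@@H]2O[C@H](CO)[C@H](O)[C@H](O)[C@H]2O)s1`) keeps the rest of compound 1 and changes only the acyl chain, by ethyl in place of hydrogen on a saturated chain carbon, nine bonds along the chain from a carbonyl carbon as the whole difference. Going by the values given here, the one measured step that bears on this is also a chain change, a 1.1-fold higher number from compound 2 to compound 3 (0.04 log units; within the scatter) as its size. It is only a loose guide, since the two compounds behind it differ from compound 1 elsewhere in the structure as well. No step beyond the scatter is therefore expected on this assay from this change, and with compound 1 recorded as "not active" (no number reported) as the starting point, a weak result or none is the likely outcome. If a number is reported at all, the estimate for compound 4 is 60000 nM as the expected value, within an expected range from 25000 nM to 150000 nM in this test.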

Compound 4, half-maximal inhibitory concentration: "not active" (no number reported)
For compound 4 the study gives words and no number; there is nothing to compare the estimate with.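

In this assay compound 1 gives "not active" (no number reported) and compound 4 gives "not active" (no number reported), so no step can be read between them. The compounds shown leave open whether any acyl chain length gives a measurable number with the free hydroxyl groups of compound 1. Nothing shown explains this result.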